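Aryl swap on the ring amine: compound 1 to compound 3

The source may hold more compounds than are shown below. What is called first, only, known or untested is meant among the compounds shown, and "the series" means these compounds.

Compound 1 `C[C@H]1CN(S(=O)(=O)C[C@]23CC[C@H](CC2=O)C3(C)C)CCN1c1ccc(C(F)(F)F)cn1` is measured in a functional assay on U2OS cells for antagonist activity at C-X-C chemokine receptor type 3 (Mus musculus) (a lower number here means a stronger inhibitor, a higher number a weaker inhibitor), at 2510 nM. Compound 2 `C[C@H]1CN(S(=O)(=O)C[C@]23CC[C@H](CC24OCCO4)C3(C)C)CCN1c1ncc(C(F)(F)F)cc1F` gives 1580 nM in this assay. Of the two numbers shown, compound 1 carries the larger, but the gap to compound 2 lies within the scatter, so no ranking between them is drawn. Compound 3 `C[C@H]1CN(S(=O)(=O)C[C@]23CC[C@H](CC2=O)C3(C)C)CCN1c1ncc(C(F)(F)F)cn1` differs from compound 1 by 5-(trifluoromethyl)pyrimidin-2-yl in place of 5-(trifluoromethyl)pyridin-2-yl on an amine nitrogen in a ring. Among the measured compounds shown here, no measured pair shows this change. For compound 3 the expected step is a 1.3-fold lower number from compound 1 to compound 3 (0.10 log units; within the scatter), nothing beyond the scatter. Compound 3 is accordingly estimated at 2000 nM in this assay, within a range of 700 nM to 6000 nM.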

Compound 3, half-maximal inhibitory concentration: 1000 nM
Beside the measured number, compound 3's estimate is 2.0-fold (0.30 log units) above it, and the stated range covers the measured number.
By their numbers in this assay, from the lowest: compounds 3, 2 and 1 (each within the scatter of the next, the first and the last beyond it).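

With the core of compound 1 held fixed, the aryl group on the ring amine responds to a single change in this assay: a 2.5-fold lower number from compound 1 to compound 3 (0.40 log units; beyond the scatter), a modest step but beyond the scatter. The two aryl groups, 5-(trifluoromethyl)pyridin-2-yl and 5-(trifluoromethyl)pyrimidin-2-yl, have equal heavy-atom counts, so swapping a ring carbon for a ring nitrogen is enough to move the number here. Nothing available bears on the reason for this step. Still open, as far as these compounds go, is whether a nitrile in place of trifluoromethyl on the pyrimidine would preserve this gain, and whether the same aryl swap would give a similar step on the core of compound 2.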